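From heptyloxy to methyl on the aromatic ring

The compounds below may be only part of what the source reports. "The series", "measured", "known", "first", "only" and "open" are said of these compounds alone.

In a functional assay on HL-60 cells (Homo sapiens) for cytotoxicity, read by WST assay, with a stated time of 48 h (a lower number here means that less compound is needed, a higher number that more compound is needed for the effect), compound 1 (`O=C1OC[C@H](Cc2ccccc2)[C@H]1Cc1ccccc1O`) gives 83000 nM as its value. Compound 2 (`COc1ccccc1C[C@H]1C(=O)OC[C@@H]1Cc1ccccc1`) gives 79000 nM on the same read-out, and compound 3 (`CCCCCCCOc1ccccc1C[C@H]1C(=O)OC[C@@H]1Cc1ccccc1`) gives 75000 nM there. All three numbers lie within the usual scatter of one another, so compound 3 stands level with the other two and not apart from them.

The next compound, compound 4 (`Cc1ccccc1C[C@H]1C(=O)OC[C@@H]1Cc1ccccc1`), carries methyl in place of heptyloxy on an aromatic carbon. The closest evidence comes from the changes made on the oxygen of compound 1. Methyl in place of the hydrogen on that oxygen gave a 1.1-fold lower number from compound 1 to compound 2 (0.02 log units; within the scatter) as its result, and heptyl in the same place gave a 1.1-fold lower number from compound 1 to compound 3 (0.04 log units; within the scatter) as its result. Going from the methyl ether to the heptyl ether gave a 1.1-fold lower number from compound 2 to compound 3 (0.02 log units; within the scatter) as its result. Each of these steps stayed within the scatter, so chain length made no visible difference among these three compounds. Within the data shown here, no measured compound lacks that oxygen, however, so this part of the change is untested. In this assay no step beyond the scatter is therefore expected, and the estimated step is a 1.1-fold higher number from compound 3 to compound 4 (0.03 log units; within the scatter) for now. For compound 4 the estimated value is 80000 nM with an expected range from 45000 nM to 130000 nM (an expectation only).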

Compound 4, half-maximal effective concentration: 57000 nM
For compound 4 the middle estimate is 1.4-fold (0.15 log units) above the measured one; the measured number falls inside the stated range.
By their numbers in this assay, from the lowest: compounds 4, 3, 2 and 1 (each within the scatter of the next).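

Among these compounds, compound 4 is the first compound in the set with no oxygen on this aromatic carbon, so it tests the part of the change that the earlier compounds could not. In this assay replacing each of the three oxygen-linked groups with methyl gives a 1.3-fold lower number from compound 3 to compound 4 (0.12 log units; within the scatter) for heptyloxy and a 1.4-fold lower number from compound 2 to compound 4 (0.14 log units; within the scatter) for methoxy and a 1.5-fold lower number from compound 1 to compound 4 (0.16 log units; within the scatter) for hydroxy and none of these steps rises above the usual variation between repeat measurements. Across compounds 1, 2, 3 and 4, then, neither the oxygen nor the length of the group on this carbon makes a visible difference, and no available measurement bears on why this is so.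

As far as these compounds go, these four compounds cover only hydroxy, two ethers and methyl on this one carbon, so it remains open whether an amine, a carboxylic acid or a chlorine atom there would shift the number beyond that variation. From the compounds shown here alone, it is also open whether changes elsewhere on the shared core, such as on the other aromatic ring, would have a larger effect than any change seen here.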